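The source may report more compounds than this note shows. Statements on the series, on what has been measured and on what is new or still open speak of the compounds shown alone.

Measured compounds in a functional assay on BGC-823 cells (Homo sapiens) for antiproliferative activity, read by MTT assay, tested at 1 uM; on this read-out higher numbers stand for a stronger effect at the one concentration tested and lower numbers for a weaker effect:
- compound 1 `COc1cc(C2=NN(C(C)=O)C(c3cc(Cl)cc(Cl)c3)O2)cc(OC)c1OC` gives 0%
- compound 2 `COc1ccc(OC)c(C2OC(c3cc(OC)c(OC)c(OC)c3)=NN2C(C)=O)c1` gives 0.4%
- compound 3 `COc1cc(C2=NN(C(C)=O)C(c3ccc(Cl)c([N+](=O)[O-])c3)O2)cc(OC)c1OC` gives -2.3%

Compound 3 holds the lowest of the three numbers in this assay, but its nearest neighbour is compound 1 and its furthest is compound 2, and both gaps are within the scatter: the three compounds cannot be told apart on these numbers.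

The unmeasured compound 4 `COc1cc(C2=NN(C(C)=O)C(c3ccc(F)c(F)c3)O2)cc(OC)c1OC` differs from compound 3 in one place: 3,4-difluorophenyl in place of 4-chloro-3-nitrophenyl on a saturated ring carbon.

Two measured steps change the aryl group on the same saturated ring carbon and so bear on this change. From compound 1 to compound 3 this assay moves a number 2.3 percentage points lower from compound 1 to compound 3 (within the scatter), and from compound 2 to compound 3 it moves a number 2.7 percentage points lower from compound 2 to compound 3 (within the scatter). Neither step leaves the scatter, and the groups swapped there differ from one another more than the 3,4-difluorophenyl of compound 4 differs from the 4-chloro-3-nitrophenyl of compound 3 in what is counted. No step beyond the scatter is therefore expected for compound 4; the expected step in this assay is a number 2.3 percentage points higher from compound 3 to compound 4 (within the scatter). Compound 4 is estimated at 0%, with a range from -8% to 8%.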

Compound 4, a percentage reported as inhibition, at one concentration (the size of the read-out at that concentration, not a potency): 18.3%
Estimate against measurement, compound 4: 18.3 percentage points below, and the stated range ends below it.
By their numbers in this assay, from the lowest: compounds 3, 1 and 2 (each within the scatter of the next); then compound 4.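

In this assay, the aryl group on this saturated ring carbon now makes a visible difference: 3,4-difluorophenyl brings a number 20.6 percentage points higher from compound 3 to compound 4 (beyond the scatter), and likewise a number 17.9 percentage points higher from compound 2 to compound 4 (beyond the scatter) and a number 18.3 percentage points higher from compound 1 to compound 4 (beyond the scatter), whereas the three earlier aryl groups could not be told apart. Halogen on the phenyl ring is not sufficient in itself, as compound 1, with 3,5-dichlorophenyl, gives 0%. Nothing given here explains the rise.

The compounds shown leave open whether both fluorine atoms of 3,4-difluorophenyl are needed, and how an unsubstituted phenyl would compare at this carbon. They also leave open what an amine or a carboxylic acid on the phenyl ring would do in this assay.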